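The compounds below may be only part of what the source reports. "The series", "measured", "known", "first", "only" and "open" are said of these compounds alone.

Measured so far:
- compound 1, `COc1ccc(C2N=C(SCc3ccc(F)cc3)NC(C)=C2C(=O)Nc2ccc(F)cc2)cc1OC` — 28.7%
- compound 2, `CC1=C(C(=O)Nc2ccc(F)cc2)C(c2ccc([N+](=O)[O-])cc2)N=C(SCc2ccccc2Cl)N1` — 15.9%

Both compounds were tested in a functional assay on the whole organism (artery, strain albino) with Rattus norvegicus as the target, with a stated time of 240 min, at a dose of 10 mg/kg by the oral route; on this read-out lower numbers stand for less inhibition and higher numbers for more inhibition at the one dose given (going by the name of the read-out). Compound 1 gives 28.7% there. Compound 2 gives 15.9%, which is the lower of the two numbers, and the gap to compound 1 is beyond the usual scatter of this measurement. Among the compounds with values here, compound 1 and compound 2 differ in more than one place, so the two values show only that compound 1 is the higher of the pair, not which part of the structure accounts for it.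

Compound 3, `CC1=C(C(=O)Nc2ccc(F)cc2)C(c2ccc([N+](=O)[O-])cc2)N=C(SCc2ccc(F)cc2)N1`, has not yet been measured. It differs from compound 2 in one place: 4-fluorophenyl in place of 2-chlorophenyl on a saturated chain carbon bound to a sulfur. The group that enters is the same one that compound 1 carries at that position. Within the data shown here, no single-change step between measured compounds is available to guide this, so the expectation rests on the two values alone.

Compound 3 is expected to give 20% in this assay, with a plausible range from 5% to 38%. The step from compound 2 is estimated at a number 4.1 percentage points higher from compound 2 to compound 3 (within the scatter), a small rise that may well lie within the scatter.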

Compound 3, a percentage reported as inhibition, in the whole organism at one dose (the size of the read-out at that dose, not a potency): 25.6%
Compound 3: middle estimate off by 5.6 percentage points, on the low side; the range from low to high includes it.
By their numbers in this assay, from the lowest: compounds 2, 3 and 1 (each within the scatter of the next, the first and the last beyond it).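

Compound 3 turns the two-place difference between compound 1 and compound 2 into two single changes that can each be read on their own. In this assay, 4-fluorophenyl in place of 2-chlorophenyl on a saturated chain carbon bound to a sulfur gives a number 9.7 percentage points higher from compound 2 to compound 3 (within the scatter), and 4-nitrophenyl in place of 3,4-dimethoxyphenyl on a saturated ring carbon gives a number 3.1 percentage points lower from compound 1 to compound 3 (within the scatter), so neither single change separates its pair of compounds beyond the scatter. Nothing available here explains these numbers.

Open, as far as these compounds go, is whether a plain phenyl, a carboxylic acid or an amine on that chain carbon would give a value beyond the scatter of these. A single oral dose also leaves open how these compounds would compare at other doses.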